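The source may report more compounds than this note shows. Statements on the series, on what has been measured and on what is new or still open speak of the compounds shown alone.

Three compounds were measured in a functional assay on cells (T-cell line, Homo sapiens) for inhibition; on this read-out higher numbers stand for weaker inhibition and lower numbers for stronger inhibition. Compound 1 `COc1ccc(CCCN2CCC(COCC3CCCCC3)CC2)cc1` gives 3000 nM, compound 2 `COc1ccc(CCCN2CCC(COC(c3ccc(Cl)cc3)c3ccc(Cl)cc3)CC2)cc1` gives 1100 nM, and compound 3 `COc1cccc(CCCN2CCC(COC(c3ccccc3)c3ccccc3)CC2)c1` gives 1500 nM. Compound 3 has the second highest of the three numbers; its nearest neighbour is compound 2 and its furthest is compound 1, and both gaps lie within the scatter, so no order among the three can be read from these values. Compound 4 `c1ccc(C(OCC2CCN(CC3CCc4ccccc4C3)CC2)c2ccccc2)cc1` has not yet been measured. It differs from compound 3 in one place: 1,2,3,4-tetrahydronaphthalen-2-yl in place of 2-(3-methoxyphenyl)ethyl on a saturated chain carbon bound to an amine nitrogen in a ring. Among the compounds with values here, no step between measured compounds covers a change of this kind, so there is no measured guide for it. The step of no change at the digits printed from compound 3 to compound 4 (within the scatter) is expected to stay within the scatter. Compound 4 is therefore estimated at 1500 nM, with a range from 500 nM to 4500 nM.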

Compound 4, half-maximal inhibitory concentration: 5600 nM
Estimate against measurement, compound 4: 3.7-fold (0.57 log units) below; the measured number lies above the stated range.
By their numbers in this assay, from the lowest: compounds 2, 3, 1 and 4 (each within the scatter of the next, the first and the last beyond it).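

Within the data shown here, at this position, on a saturated chain carbon bound to an amine nitrogen in a ring, the group cannot be swapped freely: in this assay, 1,2,3,4-tetrahydronaphthalen-2-yl in place of 2-(3-methoxyphenyl)ethyl gives a 3.7-fold higher number from compound 3 to compound 4 (0.57 log units; beyond the scatter) as the first single-place step here. The change removes the oxygen and adds a non-aromatic ring of carbon only, and this one step cannot separate those two differences. Nothing measured here accounts for the step.

Still open, from the compounds shown here alone, is whether plain 2-phenylethyl, without the oxygen, would behave like the methoxy group or like the closed ring. Going by these compounds, how a longer chain carrying an amine would fare at this position also remains unknown.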